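Swapping fluoro for chloro in compound 2

A few compounds are considered here, and "the series" means these few. Any claim that something is new, unique, unknown or untested is made for them only; others in the source may bear on it.

In an ADME assay on BHK-21 cells (Mesocricetus auratus) for cytotoxicity, read by MTT assay, with a stated time of 72 h (on this read-out higher numbers stand for lower toxicity in this test and lower numbers for higher toxicity in this test), compound 1 (`NS(=O)(=O)c1ccc(N2N=C(c3ccc(OCc4ccccc4)cc3)CC2c2ccccc2)cc1`) gives 80000 nM and compound 2 (`NS(=O)(=O)c1ccc(N2N=C(c3ccc(OCc4ccccc4)cc3)CC2c2ccc(F)cc2)cc1`) gives 60000 nM. Going by the values given here, these two values lie within the scatter of each other and together form the upper end of the three numbers known so far. Compound 3 (`Cc1cccc(C2CC(c3ccc(Oc4ccccc4)cc3)=NN2c2ccc(S(N)(=O)=O)cc2)c1`) stands apart at 8000 nM, clearly lower than both.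

The next compound to be read is compound 4 (`NS(=O)(=O)c1ccc(N2N=C(c3ccc(OCc4ccccc4)cc3)CC2c2ccc(Cl)cc2)cc1`). It differs from compound 2 by chloro in place of fluoro on an aromatic carbon, para to a large group. Among the compounds with values here, only one measured step bears on this change, a 1.3-fold lower number from compound 1 to compound 2 (0.12 log units; within the scatter), where fluoro took the place of hydrogen on an aromatic carbon, and that step stayed within the scatter. Within the data shown here, compound 3 differs from compound 2 in more than one place, so it gives no clean guide to a single swap, and no measured compound yet carries chloro.

No shift beyond the scatter is therefore expected in this assay. The expected change is a 1.2-fold lower number from compound 2 to compound 4 (0.08 log units; within the scatter), which is an estimate and remains within the scatter. For compound 4 the estimated value is 50000 nM, with an expected range of 22000 nM to 100000 nM.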

Compound 4, half-maximal cytotoxic concentration: 15000 nM
Compound 4: middle estimate off by 3.3-fold (0.52 log units), on the high side; the measured number lies below the stated range.
By their numbers in this assay, from the lowest: compounds 3 and 4 (each within the scatter of the next); then compounds 2 and 1 (each within the scatter of the next).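

In this assay this place on the ring proves not to be indifferent to the group it carries: 4-fluorophenyl to 4-chlorophenyl gives a 4.0-fold lower number from compound 2 to compound 4 (0.60 log units; beyond the scatter) and chloro in place of hydrogen gives a 5.3-fold lower number from compound 1 to compound 4 (0.73 log units; beyond the scatter) in the same series. Going by these compounds alone, the only earlier step at this place, a 1.3-fold lower number from compound 1 to compound 2 (0.12 log units; within the scatter), involved fluoro and could not separate the two compounds, so chloro is the first group here to move the number clearly downward, towards higher toxicity in this test. Nothing available explains why chloro and fluoro part ways at this place, though both are single heavy atoms without hydrogen-bond donors or acceptors.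

On these data alone, whether the downward step continues with bromo, or also appears with a methyl, a methoxy or an amine at this place, remains open. Also open, as far as these compounds go, is whether chloro would bring a step of similar size on a different core, since compound 3 differs from these compounds in more than one place and offers no clean comparison.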